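A few compounds are considered here, and "the series" means these few. Any claim that something is new, unique, unknown or untested is made for them only; others in the source may bear on it.

Of the compounds shown here, three that share a common kind of core have been tested in a toxicity assay on MT4 cells (Homo sapiens) for cytotoxicity, read by MTT assay, with a stated time of 5 days (on this read-out lower numbers stand for higher toxicity in this test and higher numbers for lower toxicity in this test), and a fourth is still waiting for its number. Compound 1 `N#C/C=C/c1cc(F)c(Oc2nc(Nc3ccc(C#N)c(F)c3)nc3ccsc23)c(F)c1` gives 96000 nM in this assay. Compound 2 `N#C/C=C/c1cc(F)c(Oc2nc(Nc3ccc(C#N)nc3)nc3ccsc23)c(F)c1` differs from compound 1 in a single place, namely (6-cyanopyridin-3-yl in place of 4-cyano-3-fluorophenyl on a nitrogen on an aromatic ring). In this assay compound 2 gives 47500 nM. That single change made a step of a 2.0-fold lower number from compound 1 to compound 2 (0.31 log units; beyond the scatter).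

Compound 3 `Cc1cc(-c2ccc(F)cc2)cc(C)c1Oc1nc(Nc2ccc(C#N)c(F)c2)nc2ccsc12` carries the same kind of core as compound 1 but a different outer portion; the difference between the two cores is not broken down here. Compound 3 gives 97300 nM in this assay, a number that sits within the usual scatter of the value of compound 1.

Compound 4 `Cc1cc(-c2ccc(F)cc2)cc(C)c1Oc1nc(Nc2ccc(C#N)nc2)nc2ccsc12` is to compound 3 what compound 2 is to compound 1: the change is 6-cyanopyridin-3-yl in place of 4-cyano-3-fluorophenyl on a nitrogen on an aromatic ring, at a place described in the same words as in the first pair, so it is the same change carried onto a different core. Among the measured compounds shown here, the only guide to what it might do is the single step seen between compound 1 and compound 2. On that basis, compound 4 is expected to land about a 1.9-fold lower number from compound 3 to compound 4 (0.29 log units; within the scatter) relative to compound 3. The estimate for compound 4 in this assay is 50000 nM, with a likely range from 25000 nM to 100000 nM, the width reflecting that a single earlier step is a thin basis.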

Compound 4, half-maximal cytotoxic concentration: 6130 nM
The estimate for compound 4 lay 8.2-fold (0.91 log units) above the measured number, outside the stated range (below it).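

In this assay, putting 6-cyanopyridin-3-yl in place of 4-cyano-3-fluorophenyl gave a 16-fold lower number from compound 3 to compound 4 (1.20 log units; beyond the scatter) and so a change that was modest on the first core proved large on the second. The number fell on both cores, which means higher toxicity in this test each time, but the size of the step did not carry over from one core to the other: the same change on two cores in this assay, a 2.0-fold lower number (0.31 log units; beyond the scatter) from compound 1 to compound 2 and a 16-fold lower number (1.20 log units; beyond the scatter) from compound 3 to compound 4, 7.9-fold (0.90 log units) apart, beyond the scatter of two such steps. This shows that, within these two pairs, the result of the change depends on the core that carries it, yet the outer portions of the two cores differ in more than one place, so the pairs cannot tell which difference matters, why it matters, or how a third core would respond.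

The compounds shown leave open whether the step would stay small or grow large on a core with an amine or a carboxylic acid in its outer portion. They also leave open whether a different group on the nitrogen, such as a plain phenyl without the nitrile, would show the same dependence on the core.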